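A fluoro to methoxy exchange at the assay limit

This account rests on a few compounds, and the source may have more. Where it says the series, first, only, none or still open, it means among the compounds named here.

Measured in an ADME assay on HaCaT cells (Homo sapiens) for cytotoxicity, read by MTT assay, with a stated time of 48 h; on this read-out higher numbers stand for weaker inhibition and lower numbers for stronger inhibition:
- Compound 1 `Fc1ccc(-c2nn(-c3ccccc3)cc2-c2nc3ccccc3[nH]2)cc1`: > 50000 nM, a limit
- Compound 2 `Fc1ccc(-c2nn(-c3ccccc3)cc2-c2nc3cc(F)ccc3[nH]2)cc1`: > 50000 nM, a limit
- Compound 3 `COc1ccc2[nH]c(-c3cn(-c4ccccc4)nc3-c3ccc(F)cc3)nc2c1`: > 50000 nM, a limit

Compound 2 stands at > 50000 nM, which is a limit of the assay and not a number. It has no readable position relative to the other two compounds, and the whole series shares one ceiling: the limit of > 50000 nM in this assay, at which 3 of the 3 values shown sit.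

Compound 4 `COc1ccc(-c2nn(-c3ccccc3)cc2-c2nc3cc(F)ccc3[nH]2)cc1` departs from compound 2 in one place, 4-fluorophenyl to 4-methoxyphenyl: methoxy in place of fluoro on an aromatic carbon. This is methoxy in place of fluoro on an aromatic carbon, para to a large group.

Among the compounds with values here, the closest precedent is a step that the two limits leave unreadable from compound 2 to compound 3, the same kind of exchange made elsewhere in the molecule. The other two measured steps are a step that the two limits leave unreadable from compound 1 to compound 2 and a step that the two limits leave unreadable from compound 1 to compound 3. None of the three has a size that can be read, so they offer no sign of a move in either direction, only the fact that all three compounds remain at the limit.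

In this assay the expected step is a number no higher from compound 2 to compound 4 (the limit leaves the size open), with no change anticipated beyond the scatter. Compound 4 is estimated at 50000 nM, with an expected range of 25000 nM to 100000 nM, and it will most likely be reported as a limit too.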

Compound 4, half-maximal inhibitory concentration: > 50000 nM
Compound 4: no number, only a limit (the forecaster's own chance of this, stated with the estimate: 85%); the middle value lies on the limit itself.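

In this assay compound 4 gives > 50000 nM, which is a limit of the assay and not a number. No size can be read for the step between compound 2 and compound 4, and the series shares one ceiling: the limit of > 50000 nM in this assay, at which 4 of the 4 values shown sit.

The compounds shown leave open whether 4-fluorophenyl to 4-methoxyphenyl changes the read-out at all.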